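The compounds below may be only part of what the source reports. "The series", "measured", "known", "first", "only" and "open" are said of these compounds alone.

Of the compounds shown here, three sharing one core have been measured in a functional assay on NCI-H460 cells (Homo sapiens) for antiproliferative activity, read by MTT assay, with a stated time of 48 h; on this read-out lower numbers stand for stronger inhibition and higher numbers for weaker inhibition. Compound 1 `COc1ccc(-c2nc3cccc(-c4cc(OC)c(OC)c(OC)c4)c3o2)cc1F` gives 2800 nM, and compound 3 `COc1cc(-c2nc3cccc(-c4cc(OC)c(OC)c(OC)c4)c3o2)ccc1O` gives 2000 nM. For the measured compounds named here, these are the only two numbers available, and a 1.4-fold lower number from compound 1 to compound 3 (0.15 log units; within the scatter) leaves the pair level. Compound 2 `COc1cc(-c2cccc3nc(-c4ccc(Cl)cc4)oc23)cc(OC)c1OC` yields only a limit, > 25000 nM.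

Compound 4 `COc1cc(-c2cccc3nc(-c4ccc5cc[nH]c5c4)oc23)cc(OC)c1OC` keeps the shared core and changes the same aromatic carbon of the five-membered aromatic ring, with 1H-indol-6-yl in place of 4-hydroxy-3-methoxyphenyl on an aromatic carbon. All three measured steps changed the group at this place. One was silent, while an at least 8.9-fold higher number from compound 1 to compound 2 (0.95 log units; beyond the scatter) and an at least 12-fold lower number from compound 2 to compound 3 (1.09 log units; beyond the scatter) were both beyond the scatter, so a swap here can either leave the number unchanged or cost a great deal. Going by the values given here, no measured compound carries the 1H-indol-6-yl group, so the direction remains uncertain, and a modest move towards weaker inhibition in this assay is expected. The expected change is a 2.5-fold higher number from compound 3 to compound 4 (0.40 log units; beyond the scatter). For compound 4 the estimated value is 5000 nM, with a range of 800 nM to 22000 nM.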

Compound 4, half-maximal inhibitory concentration: 24 nM
For compound 4 the middle estimate is 210-fold (2.32 log units) above the measured one, outside the stated range (below it).
By their numbers in this assay, from the lowest: compound 4; then compounds 3 and 1 (each within the scatter of the next). At a limit, above all of these: compound 2.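

In this assay, the aromatic carbon of the five-membered aromatic ring proved able to carry a large gain, not only a silent swap or a loss: an 83-fold lower number from compound 3 to compound 4 (1.92 log units; beyond the scatter), and a 120-fold lower number from compound 1 to compound 4 (2.07 log units; beyond the scatter). For the compounds shown here, no earlier group at this place had taken the number beyond the scatter below compound 1 and compound 3, and 1H-indol-6-yl, with its five-membered and six-membered aromatic rings, is the first to do so. The widest step, an at least 1000-fold lower number from compound 2 to compound 4 (3.01 log units; beyond the scatter), rests on a limit and not on a number: the limit of > 25000 nM in this assay, at which 1 of the 4 values shown sits.

The compounds shown leave open whether the gain needs the indole ring nitrogen, which a naphthyl group of carbon only or a benzofuranyl group at this place would test. They also leave open how the number would respond to an amine or a carboxylic acid on the indole.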